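The source may hold more compounds than are shown below. What is called first, only, known or untested is meant among the compounds shown, and "the series" means these compounds.

Compound 1 `Cc1nc(N2CCC(C)(O)CC2)nc2ccc(NC(=O)COc3ccc(Cl)cc3)cc12` gives 237 nM in an assay on CHO-K1 cells for displacement of a labelled ligand from melanin-concentrating hormone receptor 1 (Homo sapiens), with a stated time of 2 h (on this read-out lower numbers stand for stronger inhibition and higher numbers for weaker inhibition), the highest of the three numbers in hand: compound 2 `Cc1nc(N2CCN(C3CCOCC3)CC2)nc2ccc(NC(=O)COc3ccc(OC(F)(F)F)cc3)cc12` gives 7 nM and compound 3 `Cc1nc(N2CCN(C(=O)C3CCC3)CC2)nc2ccc(NC(=O)COc3ccc(OC(F)(F)F)cc3)cc12` gives 84 nM. Compound 4 `CCC1(O)CCN(c2nc(C)c3cc(NC(=O)COc4ccc(Cl)cc4)ccc3n2)CC1` differs from compound 1 by methyl in place of hydrogen on a saturated chain carbon bound to a saturated ring carbon. Among the measured compounds shown here, the only measured single change, a 12-fold higher number from compound 2 to compound 3 (1.08 log units; beyond the scatter), alters the group on an amine nitrogen in a ring of a different compound pair and does not touch the place changed here. For the measured compounds named here, no measured step bears directly on the change from compound 1 to compound 4, and for such a small addition no shift beyond the scatter is expected. The step expected is therefore a 1.2-fold lower number from compound 1 to compound 4 (0.07 log units; within the scatter). Compound 4 is estimated at 200 nM, with a range from 80 nM to 600 nM.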

Compound 4, half-maximal inhibitory concentration: 208 nM
Estimate against measurement, compound 4: 1.0-fold (0.02 log units) below; low and high end bracket the measured number.
By their numbers in this assay, from the lowest: compound 2; then compound 3; then compounds 4 and 1 (each within the scatter of the next).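

Replacing 4-hydroxy-4-methylpiperidin-1-yl with 4-ethyl-4-hydroxypiperidin-1-yl gives a 1.1-fold lower number from compound 1 to compound 4 (0.06 log units; within the scatter) in this assay, so this place accepts one added methyl with no shift that stands out from the scatter. Among the compounds shown here, this is the first measured step at this place, whereas the earlier compounds showed only a change on an amine nitrogen in a ring. No measurement at hand offers an explanation for this flat step. Still open, on these data alone, is how large a group, such as a propyl chain or a phenyl ring, this place can carry before the number moves. As far as these compounds go, whether an amine in place of the hydroxyl group would alter the number also remains open.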